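Swapping 3-chlorophenyl for 4-nitrophenyl: what to expect

The compounds below may be only part of what the source reports. "The series", "measured", "known", "first", "only" and "open" are said of these compounds alone.

Compound 1 `CCCCCCCCCCCCCCNC(=O)[C@H](CO)/N=C/c1cccc(OC)c1`: 77300 nM
Compound 2 `CCCCCCCCCCCCCCNC(=O)[C@H](CO)/N=C/c1cccc(Cl)c1`: 77000 nM

Within the data shown here, in an ADME assay on HEK293 cells (Homo sapiens) for cytotoxicity (a lower number here means a stronger inhibitor, a higher number a weaker inhibitor), compound 2, at 77000 nM, stands within the scatter of compound 1, so the two sit level on the numbers so far. The next compound, compound 3 `CCCCCCCCCCCCCCNC(=O)[C@H](CO)/N=C/c1ccc([N+](=O)[O-])cc1`, has not yet been measured. It departs from compound 2 with 4-nitrophenyl in place of 3-chlorophenyl on a carbon with a double bond to nitrogen.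

Among the measured compounds shown here, only one measured step bears on this change: a 1.0-fold lower number from compound 1 to compound 2 (0.00 log units; within the scatter). That step, chloro in place of methoxy on an aromatic carbon, lies within the scatter. It is thin evidence, since neither compound 1 nor compound 2 carries a 4-nitrophenyl group. As far as these compounds go, with nothing else to go on, no shift beyond the scatter is expected in this assay, and the direction stays open. The expected size is a 1.1-fold lower number from compound 2 to compound 3 (0.04 log units; within the scatter). For compound 3 the estimated value is 70000 nM, with an expected range of 35000 nM to 140000 nM.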

Compound 3, half-maximal inhibitory concentration: 49500 nM
Compound 3: middle estimate off by 1.4-fold (0.15 log units), on the high side; measured number inside the range.
By their numbers in this assay, from the lowest: compounds 3, 2 and 1 (each within the scatter of the next).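

In this assay, the change at the carbon with a double bond to nitrogen stays within the scatter (a 1.6-fold lower number from compound 2 to compound 3 (0.19 log units; within the scatter)), and the same holds against the methoxy compound (a 1.6-fold lower number from compound 1 to compound 3 (0.19 log units; within the scatter)). Among these compounds, the earlier pair had compared only two groups on the same ring place, so this result extends the level picture to a different substituent, 4-nitrophenyl, which brings hydrogen-bond acceptors and a double bond outside the aromatic ring that 3-chlorophenyl lacks. Across compound 1, compound 2 and compound 3, neither this exchange of aryl groups nor the change of ring place that comes with it separates the numbers beyond the scatter. Nothing available explains this level result or ties it to any feature of these groups.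

The compounds shown leave open whether an aryl group carrying an amine or a carboxylic acid would stay equally level, and whether 3-nitrophenyl or 4-chlorophenyl would do so too. They also leave open how far the numbers depend on the long alkyl chain, since all three compounds share it and a shorter chain does not appear among them.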